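Swapping ethoxy for fluoro: what to expect of compound 4

This account rests on a few compounds, and the source may have more. Where it says the series, first, only, none or still open, it means among the compounds named here.

compound 1 `CCS(=O)(=O)c1ccc(COC[C@@H]2C[C@@H]2C2CCN(c3nc(C(C)C)no3)CC2)c(F)c1` gives 1.5 h
compound 2 `O=S(=O)(CCO)c1ccc(COC[C@@H]2C[C@@H]2C2CCN(c3ncc(Cl)cn3)CC2)c(F)c1` gives 0.9 h
compound 3 `CCOc1cnc(N2CCC([C@H]3C[C@H]3COCc3ccc(S(C)(=O)=O)c(F)c3)CC2)nc1` gives 0.8 h

Compound 3 gives 0.8 h in an ADME assay on the whole organism (strain Wistar Han) for metabolic stability, with Rattus norvegicus as the target, read by LC-MS, at a dose of 0.5 mg/kg by the intravenous route (on this read-out lower numbers stand for a shorter-lived compound and higher numbers for a longer-lived compound), and so lies within the usual scatter of both compound 2 and compound 1, which means these numbers do not rank it against either. Compound 4 `CS(=O)(=O)c1ccc(COC[C@@H]2C[C@@H]2C2CCN(c3ncc(F)cn3)CC2)cc1F` is still unmeasured. It differs from compound 3 at one place, with fluoro in place of ethoxy on an aromatic carbon, turning 5-ethoxypyrimidin-2-yl into 5-fluoropyrimidin-2-yl. Among the compounds with values here, no measured pair differs in one place only, so the data offer no direct precedent for this change. Within the data shown here, the only guide is that compound 2 at 0.9 h and compound 1 at 1.5 h both stay within the scatter of compound 3 despite differing from it in more than one place. In this assay the expected step is a 1.3-fold higher number from compound 3 to compound 4 (0.10 log units; within the scatter) and thus none beyond the scatter. In this assay the estimate for compound 4 is 1 h (range 0.5 h to 2 h).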

Compound 4, half-life: 1.5 h
For compound 4 the middle estimate is 1.5-fold (0.18 log units) below the measured one; the range from low to high includes it.
By their numbers in this assay, from the lowest: compounds 3, 2, 1 and 4 (each within the scatter of the next).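

In this assay, within the data shown here, the exchange of 5-ethoxypyrimidin-2-yl for 5-fluoropyrimidin-2-yl provides the first comparison in which only one place differs, and a 1.9-fold higher number from compound 3 to compound 4 (0.27 log units; within the scatter) stays within the usual scatter. At this position, then, replacing the three heavy atoms of ethoxy and its hydrogen-bond acceptor with a single fluorine does not separate the two compounds on this read-out. Nothing measured here explains this result.

The compounds shown leave open whether any other group at this position, such as an amine or a propoxy chain, would shift the half-life beyond the scatter. They also leave open whether the same exchange would give a similar step with an ethyl group in place of methyl on the sulfonyl.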